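This account rests on a few compounds, and the source may have more. Where it says the series, first, only, none or still open, it means among the compounds named here.

Of the compounds shown here, three that share one core have been measured in a functional assay on CHO cells for antagonist activity at sphingosine 1-phosphate receptor 2 (Homo sapiens), read by calcium flux; on this read-out higher numbers stand for weaker inhibition and lower numbers for stronger inhibition. Compound 1 `C[C@@H](C(=O)O)c1nn(Cc2cn3cc(OCC4CC4)c(Cl)cc3n2)c2ccccc2c1=O` gives 24 nM. Compound 2 `CC(C(=O)O)c1nn(Cc2cn3cc(OCC4CC4)c(C(F)(F)F)cc3n2)c2ccccc2c1=O`, which carries a trifluoromethyl group where the other two carry chlorine, gives 3.4 nM. Compound 3 `O=C(O)C1(c2nn(Cc3cn4cc(OCC5CC5)c(Cl)cc4n3)c3ccccc3c2=O)CC1` gives 16 nM. Among the three numbers compound 3 stands second highest: its nearest neighbour is compound 1, within the scatter, and compound 2 lies furthest away, beyond the scatter.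

Going by the values given here, only one step joins two measured compounds that differ in a single place, a 1.5-fold lower number from compound 1 to compound 3 (0.18 log units; within the scatter), and it came with 1-carboxycyclopropyl in place of 1-carboxyethyl on an aromatic carbon. Compound 4 `CC(C(=O)O)c1nn(Cc2cn3cc(OCC4CC4)c(Cl)cc3n2)c2ccccc2c1=O` is reached from compound 3 by the reverse exchange, (1-carboxyethyl in place of 1-carboxycyclopropyl on an aromatic carbon). Because that earlier step a 1.5-fold lower number from compound 1 to compound 3 (0.18 log units; within the scatter) stayed within the scatter, no movement beyond the scatter is expected on going back. Compound 4 bears the same 1-carboxyethyl group as compound 1, which gives 24 nM and serves as the reference point. The expected step is a 1.6-fold higher number from compound 3 to compound 4 (0.21 log units; within the scatter). For compound 4 the estimate is 26 nM, with a range from 11 nM to 65 nM.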

Compound 4, half-maximal inhibitory concentration: 6 nM
Compound 4: middle estimate off by 4.3-fold (0.64 log units), on the high side; the measured number lies below the stated range.
By their numbers in this assay, from the lowest: compounds 2 and 4 (each within the scatter of the next); then compounds 3 and 1 (each within the scatter of the next).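

The exchange of 1-carboxycyclopropyl for 1-carboxyethyl at this position now gives a 2.7-fold lower number from compound 3 to compound 4 (0.43 log units; beyond the scatter), while the step of a 1.5-fold lower number from compound 1 to compound 3 (0.18 log units; within the scatter) had suggested the two groups could not be told apart, so the reading of this exchange depends on which 1-carboxyethyl compound is taken. Compound 1 and compound 4 share all atoms and bonds, yet the step is a 4.0-fold lower number from compound 1 to compound 4 (0.60 log units; beyond the scatter), and the only thing that separates them is this: the fact that one of compounds 1 and 4 is drawn with a defined configuration and the other without, at the place where they differ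

Among compounds drawn without a configuration at this carbon, chloro in place of trifluoromethyl gives a 1.8-fold higher number from compound 2 to compound 4 (0.25 log units; within the scatter).

The compounds shown leave open how a 1-carboxyethyl compound drawn with the opposite configuration to compound 1 would read. They also leave open whether a carboxymethyl or a 1-carboxypropyl group at this position would behave like 1-carboxyethyl.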